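The compounds below may be only part of what the source reports. "The series", "measured", "known", "first", "only" and "open" are said of these compounds alone.

Measured so far, in a functional assay on HOP-62 cells (Homo sapiens) for cytotoxicity, read by sulforhodamine B assay, with a stated time of 48 h, tested at 1 uM; a higher number here means a weaker effect of the compound at the concentration tested, a lower number a stronger effect:

Compound 1 `COc1cc(-c2cc(/C=C/C(=O)c3ccc(N)cc3)[nH]n2)cc(OC)c1OC` gives 86%.
Compound 2 `COc1ccc(-c2cc(/C=C/C(=O)c3ccc(N)cc3)[nH]n2)cc1OC` gives 92%.
Compound 3 `COc1cc(C(=O)/C=C/c2cc(-c3cc(OC)c(OC)c(OC)c3)n[nH]2)cc(OC)c1OC` gives 78%.

Compounds 1 and 2 share a core and differ in one place: hydrogen in place of methoxy on an aromatic carbon. The step it made in this assay is a number 6 percentage points higher from compound 1 to compound 2 (within the scatter), so within this pair the change leaves the read-out essentially where it was.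

Compound 3 is built on a different core; its difference from compound 1 is not broken down here. Compared with compound 1, compound 3 sits close, the gap between the two values lying inside the usual scatter, while against compound 2 the gap is larger than the scatter.

Compound 4 `COc1ccc(-c2cc(/C=C/C(=O)c3cc(OC)c(OC)c(OC)c3)[nH]n2)cc1OC` is not yet measured. It differs from compound 3 in the same way that compound 2 differs from compound 1: hydrogen in place of methoxy on an aromatic carbon. The place lines of both changes read the same word for word, so the change is counted as the same kind on a different core.

Going by the values given here, for compound 4 in this assay the expected step is a number 6 percentage points higher from compound 3 to compound 4 (within the scatter), resting on the only measured instance of this change, the step of a number 6 percentage points higher from compound 1 to compound 2 (within the scatter), which stayed within the scatter. Whether the second core answers the change in the same way is not shown by any measured pair, so the range is kept wide. The estimate for compound 4 is 84%, expected between 70% and 97%.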

Compound 4, a percentage reported as activity, at one concentration (the size of the read-out at that concentration, not a potency): 71%
For compound 4 the middle estimate is 13 percentage points above the measured one; measured number inside the range.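

In this assay, hydrogen in place of methoxy on an aromatic carbon gives a step of a number 7 percentage points lower from compound 3 to compound 4 (within the scatter). Set beside the earlier instance of the same change, this step does not separate the two cores: the same change on two cores in this assay, a number 6 percentage points higher (within the scatter) from compound 1 to compound 2 and a number 7 percentage points lower (within the scatter) from compound 3 to compound 4, 13 percentage points apart, within the scatter of two such steps In these two pairs, the change therefore carries over as a step that stays inside the usual scatter on both cores, and neither step supports a direction for the change; this rests on two pairs, one cell line and a single tested concentration, so it shows neither that the methoxy group is dispensable in general nor how the change would behave on any further core or in a measure of potency.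

The compounds shown leave open whether a group other than hydrogen in that place, such as a hydroxyl group, a chlorine atom or a longer chain like ethoxy, would give a step beyond the scatter on either core. They also leave open whether the same change at another methoxy group of these compounds would stay as small as the two steps seen here.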